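Adding a Methyl to the Diaryl Ether of Compound 1

The source may report more compounds than this note shows. Statements on the series, on what has been measured and on what is new or still open speak of the compounds shown alone.

Going by the values given here, compound 1 `Cc1cccc(C)c1Oc1cc(Nc2ccc(C#N)cc2)[nH]c(=O)c1Cl` is one of three compounds measured in an ADME assay on MT4 cells (Homo sapiens) for cytotoxicity, read by MTT assay, with a stated time of 5 days (a higher number here means that more compound is tolerated, a lower number that less compound is tolerated), where compound 1 gives 29000 nM. It stands second highest of the three: compound 2 `Cc1cccc(C)c1Oc1cc(Nc2ccc(C#N)cc2)[nH]c(=O)c1` gives 36000 nM, and compound 3 `COc1cc(Oc2c(C)cc(C)cc2C)cc(Nc2ccc([N+](=O)[O-])cc2)n1` gives 7200 nM, a number beyond the scatter below that of compound 1. Among the compounds with values here, the only single-point step, a 1.2-fold higher number from compound 1 to compound 2 (0.09 log units; within the scatter), is within the scatter. Compound 4 `Cc1cc(C)c(Oc2cc(Nc3ccc(C#N)cc3)[nH]c(=O)c2Cl)c(C)c1` differs from compound 1 by methyl in place of hydrogen on an aromatic carbon, the new methyl sitting meta to two methyl groups and para to a large group. Within the data shown here, no measured step covers a methyl entering in place of hydrogen, so nothing here points to a change beyond the scatter. Compound 4 is therefore expected to give 25000 nM, between 12000 nM and 50000 nM, a step of a 1.2-fold lower number from compound 1 to compound 4 (0.06 log units; within the scatter).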

Compound 4, half-maximal cytotoxic concentration: > 329000 nM
Compound 4: no number, only a limit; the forecaster's own chance of this, stated with the estimate: 5%; middle value at least 13-fold (1.11 log units) away from the limit.
By their numbers in this assay, from the lowest: compound 3; then compounds 1 and 2 (each within the scatter of the next). At a limit, above all of these: compound 4.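

On the step from 2,6-dimethylphenyl to 2,4,6-trimethylphenyl, this assay moves by an at least 11-fold higher number from compound 1 to compound 4 (1.05 log units; beyond the scatter), whereas swapping chloro for hydrogen on the core gave only a 1.2-fold higher number from compound 1 to compound 2 (0.09 log units; within the scatter), within the scatter. This position, para to a large group, is therefore one where a single methyl in place of hydrogen goes with far more compound being tolerated. For compound 4, > 329000 nM is a limit of the assay and not a number.

The compounds shown leave open whether an ethyl, a methoxy or an amine on this carbon would go the same way. Going by these compounds, how far the true number of compound 4 lies past its limit also remains open.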